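Swapping one halogen on a cytotoxic compound

A few compounds are considered here, and "the series" means these few. Any claim that something is new, unique, unknown or untested is made for them only; others in the source may bear on it.

Values so far in a functional assay on SK-MEL-147 cells (Homo sapiens) for cytotoxicity, read by MTT assay, with a stated time of 24 h (a lower number here means that less compound is needed, a higher number that more compound is needed for the effect), are these:
Compound 1 `CCOC(=O)c1cc([Se]c2ccccc2)c2cc(Br)ccc2n1` gives 12400 nM 
Compound 2 `COc1ccc([Se]c2cc(-c3ccc(O)cc3)nc3ccc(OC)cc23)cc1` gives 59200 nM 

Compound 1 holds the lower of these two numbers, and compound 2 lies above it by more than the usual scatter. Among the compounds with values here, the data contain no step between measured compounds that differ in one place, so no measured step can size the next change.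

That change leads to compound 3 `CCOC(=O)c1cc([Se]c2ccccc2)c2cc(Cl)ccc2n1`, which keeps the core of compound 1 and differs from it in one group (chloro in place of bromo on an aromatic carbon). The exchanged halogen sits meta to a fused ring and para to a fused ring.

The expectation in this assay is anchored on compound 1 at 12400 nM and, with only one halogen exchanged for another, it is for no step beyond the scatter. The expected change is a 1.1-fold higher number from compound 1 to compound 3 (0.05 log units; within the scatter) in this estimate. The estimate for compound 3 is 14000 nM within an expected range of 6000 nM to 32000 nM on repeated measurement.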

Compound 3, half-maximal effective concentration: 47100 nM
For compound 3 the middle estimate is 3.4-fold (0.53 log units) below the measured one; the whole stated range lies below it.
By their numbers in this assay, from the lowest: compound 1; then compounds 3 and 2 (each within the scatter of the next).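

In this assay, within the data shown here, placing chloro instead of bromo on this aromatic carbon, meta to a fused ring and para to a fused ring, gives a 3.8-fold higher number from compound 1 to compound 3 (0.58 log units; beyond the scatter), the first measured step in this set between compounds that differ in one place. It shows that this position is not indifferent to which halogen it carries: the rest of the structure stays the same, the exchange involves no ring, no hydrogen-bond donor or acceptor and no net charge, and yet more compound is needed for the effect with chloro than with bromo. Nothing measured here accounts for this difference between the two halogens.

The compounds shown leave open how fluoro, iodo or a methoxy group on this same carbon would compare with bromo, and so whether the step from bromo to chloro is part of a trend across the halogens or stands alone. They also leave open whether the same exchange would give a step of similar size on a different core or in cells other than those of this assay.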